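The source may report more compounds than this note shows. Statements on the series, on what has been measured and on what is new or still open speak of the compounds shown alone.

Of the compounds shown here, two have been tested in a functional assay on L1210 cells (Mus musculus) for inhibition; a lower number here means a stronger inhibitor, a higher number a weaker inhibitor. Compound 1 `O=c1[nH]c(=O)n(COCCO)cc1/C=C/Br` sits at the limit of the assay: in this assay compound 1 gives > 1000 ug/mL, a limit rather than a number. Within the data shown here, compound 2 `CC(=O)OCCOCn1cnc2c(Cl)ncnc21` is the only compound with a measured number; in this assay compound 2 gives 44 ug/mL. Compound 2 therefore stands alone as the one number shown, the other value being the limit (the limit of > 1000 ug/mL in this assay, at which 1 of the 2 values shown sits).

Compound 3 `CC(=O)OCCOCn1cnc2c(Cl)nc(Cl)nc21` is not yet measured. It differs from compound 2 by chloro in place of hydrogen on an aromatic carbon, the new group sitting on an aromatic carbon of a six-membered aromatic ring with 2 nitrogen, part of a fused or bridged system of two rings. Among the measured compounds shown here, no measured pair shows such a change, so the expected step is small: the step of a 1.4-fold higher number from compound 2 to compound 3 (0.13 log units; within the scatter) is expected to stay within or just beyond the scatter, if anything toward weaker inhibition. For compound 3 the estimate in this assay is 60 ug/mL, with a range from 15 ug/mL to 250 ug/mL.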

Compound 3, concentration for 50% inhibition: 12 ug/mL
Beside the measured number, compound 3's estimate is 5.0-fold (0.70 log units) above it; measured number below the stated range.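

In this assay the series now has its first step that can be read: a 3.7-fold lower number from compound 2 to compound 3 (0.56 log units; beyond the scatter), with chloro in place of hydrogen on an aromatic carbon between two ring nitrogen atoms. This position therefore responds to substitution, and in this one pair a chloro group there goes with stronger inhibition, with the chloro group meta to it kept in place. Nothing shown accounts for the step, which rests on a single pair.

On these data alone, whether the gain is specific to chloro stays open, as an amine, a methoxy group or a methyl group on the same carbon would be needed to tell. Among these compounds, compound 1 gives > 1000 ug/mL, which is a limit, and it differs from the other two compounds in more than one place, so it adds no step.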